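This account rests on a few compounds, and the source may have more. Where it says the series, first, only, none or still open, it means among the compounds named here.

Three members of the series have numbers in a functional assay on CCRF-CEM cells (Homo sapiens) for inhibition, read by sulforhodamine B assay, with a stated time of 48 h; on this read-out lower numbers stand for stronger inhibition of growth and higher numbers for weaker inhibition of growth. Compound 1 `COc1cc(-c2cc(/C=C/C(=O)c3ccc(N)cc3)[nH]n2)cc(OC)c1OC` gives 550 nM; compound 2 `COc1ccc(C(=O)/C=C/c2cc(-c3cc(OC)c(OC)c(OC)c3)n[nH]2)cc1OC` gives 620 nM; compound 3 `COc1ccc(C(=O)/C=C/c2cc(-c3cc(OC)c(OC)c(OC)c3)n[nH]2)cc1` gives 1420 nM. Compound 3 thus stands at the high end of the three: a 2.3-fold higher number from compound 2 to compound 3 (0.36 log units; beyond the scatter) and a 2.6-fold higher number from compound 1 to compound 3 (0.41 log units; beyond the scatter) both lie beyond the scatter, whereas a 1.1-fold higher number from compound 1 to compound 2 (0.05 log units; within the scatter) does not.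

Compound 4 `COc1cc(-c2cc(/C=C/C(=O)c3ccc(F)c(F)c3)[nH]n2)cc(OC)c1OC` awaits measurement. Relative to compound 3 the change is 3,4-difluorophenyl in place of 4-methoxyphenyl on a carbonyl carbon. Among the measured compounds shown here, no measured step exchanges a methoxyphenyl for a fluorinated ring, so the earlier steps bear on this only indirectly. For the measured compounds named here, the one exchange of the whole ring on the same carbonyl carbon, a 1.1-fold higher number from compound 1 to compound 2 (0.05 log units; within the scatter), stayed within the scatter; the one removal of a methoxy group from that ring, a 2.3-fold higher number from compound 2 to compound 3 (0.36 log units; beyond the scatter), raised the number modestly. Compound 4 also lacks that methoxy group, and the ring it brings in carries no hydrogen-bond acceptor. Compound 4 is therefore expected to give a number close to or modestly higher in this assay, a 1.5-fold higher number from compound 3 to compound 4 (0.19 log units; within the scatter). Compound 4 is estimated at 2200 nM, with a range from 900 nM to 5500 nM.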

Compound 4, concentration for 50% growth inhibition: 3800 nM
The estimate for compound 4 lay 1.7-fold (0.24 log units) below the measured number; measured number inside the range.
By their numbers in this assay, from the lowest: compounds 1 and 2 (each within the scatter of the next); then compound 3; then compound 4.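

Unlike the earlier whole-ring exchange on this carbonyl carbon (a 1.1-fold higher number from compound 1 to compound 2 (0.05 log units; within the scatter)), which stayed within the scatter, the entry of 3,4-difluorophenyl in this assay moves the number beyond the scatter against each of the other three rings: (a 2.7-fold higher number from compound 3 to compound 4 (0.43 log units; beyond the scatter)), (a 6.1-fold higher number from compound 2 to compound 4 (0.79 log units; beyond the scatter)) and (a 6.9-fold higher number from compound 1 to compound 4 (0.84 log units; beyond the scatter)). The position therefore does not accept every substituted phenyl ring alike, and compound 4 is the weakest of the four, with the direct exchange of the two methoxy groups for fluorine (a 6.1-fold higher number from compound 2 to compound 4 (0.79 log units; beyond the scatter)) showing that a ring substituted at the same two places does not hold the number of compound 2. Nothing shown accounts for this rise.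

Open, going by these compounds, is whether the rise follows from the fluorine atoms themselves or simply from the loss of the methoxy groups, a question that 4-fluorophenyl, 3-fluorophenyl or unsubstituted phenyl on the same carbonyl carbon would help to separate. Also open, on these data alone, is how a ring carrying hydroxy, chloro or dimethylamino groups would stand against the 4-aminophenyl of compound 1 and the 3,4-dimethoxyphenyl of compound 2.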